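Series notes: chloro in place of ethoxy on the core

The source may report more compounds than this note shows. Statements on the series, on what has been measured and on what is new or still open speak of the compounds shown alone.

Compound 3 `CCOc1nc(-c2ccc(Cl)cc2Cl)c(CC)nc1NC(CC)CC` stands highest of the three numbers in an in vitro ADME assay on microsomes (Homo sapiens) for metabolic stability; a lower number here means that the compound disappears faster, a higher number that the compound lasts longer: compound 3 gives 2 h. Its nearest neighbour is compound 2 `CCc1nc(NC(CC)CC)c(F)nc1-c1ccc(Cl)cc1Cl`, which in this assay gives 1.22 h; the step of a 1.6-fold higher number from compound 2 to compound 3 (0.21 log units; within the scatter) lies within the scatter. Compound 1 `CCc1nc(-c2ccc(Cl)cc2Cl)c(CC)nc1NC(CC)CC` is furthest, giving 0.283 h in this assay, with a 7.1-fold higher number from compound 1 to compound 3 (0.85 log units; beyond the scatter) and, against compound 2, a 4.3-fold higher number from compound 1 to compound 2 (0.63 log units; beyond the scatter).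

Compound 4 `CCc1nc(NC(CC)CC)c(Cl)nc1-c1ccc(Cl)cc1Cl` differs from compound 3 as follows: chloro in place of ethoxy on an aromatic carbon. Going by the values given here, no measured step replaces ethoxy with chloro. Among the compounds with values here, the steps that bear on it are a 4.3-fold higher number from compound 1 to compound 2 (0.63 log units; beyond the scatter), where a halogen in place of ethyl raised the number, and a 1.6-fold higher number from compound 2 to compound 3 (0.21 log units; within the scatter), where ethoxy in place of a halogen changed nothing beyond the scatter. Read together, a halogen at this place stands close to ethoxy, so compound 4 is expected to stay near compound 2 and compound 3, and the step of a 1.7-fold lower number from compound 3 to compound 4 (0.22 log units; within the scatter) is expected to remain within the scatter. Compound 4 is estimated at 1.2 h, with a range from 0.6 h to 2.4 h.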

Compound 4, half-life: 0.167 h
Beside the measured number, compound 4's estimate is 7.2-fold (0.86 log units) above it, outside the stated range (below it).
By their numbers in this assay, from the lowest: compounds 4 and 1 (each within the scatter of the next); then compounds 2 and 3 (each within the scatter of the next).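

Within this assay the two halogens do not behave alike on this aromatic carbon next to the ring nitrogen: chloro in place of fluoro gives a 7.3-fold lower number from compound 2 to compound 4 (0.86 log units; beyond the scatter) and the position cannot be read as simply tolerating a halogen. Chloro in place of ethoxy gives a 12-fold lower number from compound 3 to compound 4 (1.08 log units; beyond the scatter) and this is the largest step in the series so far, whereas chloro in place of ethyl gives a 1.7-fold lower number from compound 1 to compound 4 (0.23 log units; within the scatter) and leaves those two groups indistinguishable at this place. The higher numbers at this position therefore belong to fluoro and ethoxy among the groups shown, and nothing available accounts for the split between the two halogens.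

Open, from the compounds shown here alone, is whether methoxy, a longer alkoxy chain such as propoxy, or an amino group at this carbon would sit with fluoro and ethoxy or with chloro and ethyl. Also open, going by these compounds, is where bromo would fall, which would show whether chloro is an isolated case among the halogens here.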